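The compounds below may be only part of what the source reports. "The series", "measured", "known", "first", "only" and "open" are said of these compounds alone.

Measured so far in an assay on cells for inhibition of cytochrome P450 11B2, mitochondrial (Homo sapiens), read by HTRF; a higher number here means a weaker inhibitor, a lower number a stronger inhibitor:
- compound 1 `C[C@@H](NS(C)(=O)=O)c1cncc(N2C(=O)c3ccc(Cl)cc3C2(C)C)c1`: 8 nM
- compound 2 `CCS(=O)(=O)N1CC(Oc2cncc(N3C(=O)c4ccc(Cl)cc4C3(C)C)c2)C1`: 4 nM
- compound 3 `CC1(C)c2cc(Cl)ccc2C(=O)N1c1cncc(OC2CN(C(=O)c3ncccc3Cl)C2)c1`: 5 nM

All three share the same core and differ only in the group hung from the middle pyridine ring. Compound 2 sits at the low end of these three numbers, yet neither neighbour is clearly apart from it: the gap to compound 3 is a 1.3-fold higher number from compound 2 to compound 3 (0.10 log units; within the scatter), and compound 1 also lies within the usual scatter of compound 2.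

Compound 4 `CC(=O)N1CC[C@H](Oc2cncc(N3C(=O)c4ccc(Cl)cc4C3(C)C)c2)C1` is built from compound 2 by the following change: a group of 8 heavy atoms (6 carbon, 1 nitrogen, 1 oxygen; one five-membered non-aromatic ring with 1 hetero atom) in place of a group of 9 heavy atoms (5 carbon, 1 nitrogen, 2 oxygen, 1 sulfur; one four-membered non-aromatic ring with 1 hetero atom), on an oxygen on an aromatic ring.

Among the compounds with values here, only one measured step bears on this region, a 1.3-fold higher number from compound 2 to compound 3 (0.10 log units; within the scatter), which exchanged the group on the ring amine nitrogen and moved the number hardly at all. Within the data shown here, no measured step exchanges the small ring itself, so there is no direct guide for that part of the change. Given how tightly all three numbers cluster, a step of no more than the scatter is expected, with a slight lean towards a higher number because a 1.3-fold higher number from compound 2 to compound 3 (0.10 log units; within the scatter) already leaned that way. For compound 4 the expected step is a 1.8-fold higher number from compound 2 to compound 4 (0.24 log units; within the scatter), and its estimated value is 7 nM, in a range from 3 nM to 18 nM.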

Compound 4, half-maximal inhibitory concentration: 7 nM
Estimate against measurement, compound 4: no gap at the digits printed, and the stated range covers the measured number.
By their numbers in this assay, from the lowest: compounds 2, 3, 4 and 1 (each within the scatter of the next).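

In this assay, a 1.8-fold higher number from compound 2 to compound 4 (0.24 log units; within the scatter), so the ring and the group on its nitrogen can change together with the number staying within the scatter, whereas the earlier step changed only the nitrogen group. The open-chain group of compound 1 and the larger ring-bearing group of compound 4, each attached to the same aromatic carbon, also give a step within the scatter, a 1.1-fold lower number from compound 1 to compound 4 (0.06 log units; within the scatter). No evidence is available to explain these results.

Within the data shown here, every step so far stays within the scatter, so it remains open which change at this position would move the number clearly in either direction. As far as these compounds go, a free amine in place of the acetyl group, a carboxylic acid on a longer chain and the mirror-image form of the defined stereocentre in compound 4 all remain untested here.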